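The source may hold more compounds than are shown below. What is called first, only, known or untested is meant among the compounds shown, and "the series" means these compounds.

Of the compounds shown here, three sharing one core have been measured in a functional assay for inhibition, with Rattus norvegicus as the target; a lower number here means a stronger inhibitor, a higher number a weaker inhibitor. Compound 1 (`CC(C)C(C)/N=c1\c(O)c(O)\c1=N/c1ccc(C#N)cc1`) gives 1900 nM, compound 2 (`CCC(CC)/N=c1\c(O)c(O)\c1=N/c1ccc(C#N)cc1`) gives 3340 nM, and compound 3 (`CCC(C)/N=c1\c(O)c(O)\c1=N/c1ccc(C#N)cc1`) gives 2100 nM. Compound 3 stands within the scatter of both others. The two steps that reach it are a 1.1-fold higher number from compound 1 to compound 3 (0.04 log units; within the scatter) and a 1.6-fold lower number from compound 2 to compound 3 (0.20 log units; within the scatter).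

Compound 4 (`CCC(C)(C)/N=c1\c(O)c(O)\c1=N/c1ccc(C#N)cc1`) differs from compound 3 by methyl in place of hydrogen on a saturated chain carbon bound to a double-bonded nitrogen and two saturated chain carbons. This places methyl in place of hydrogen on a saturated chain carbon bound to a double-bonded nitrogen and two saturated chain carbons, turning sec-butyl into 1,1-dimethylpropyl. For the measured compounds named here, no measured step alters that carbon, so the evidence is only indirect. The two steps above exchange methyl and hydrogen elsewhere on the chain, and both stay within the scatter. On that basis, no change beyond the scatter is expected in this assay, and no direction can be favoured. The expected size is a 1.1-fold lower number from compound 3 to compound 4 (0.04 log units; within the scatter). For compound 4 the estimated value is 1900 nM, with an expected range of 800 nM to 4500 nM.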

Compound 4, half-maximal inhibitory concentration: > 30000 nM
Compound 4 was reported as a limit; the forecaster's own chance of this, stated with the estimate: 3%; middle value at least 15-fold (1.19 log units) away from the limit.
By their numbers in this assay, from the lowest: compounds 1, 3 and 2 (each within the scatter of the next). At a limit, above all of these: compound 4.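

In this assay, compound 4 stands at a limit of the assay, not at a number: the limit of > 30000 nM in this assay, at which 1 of the 4 values shown sits. Methyl in place of hydrogen on a saturated chain carbon bound to a double-bonded nitrogen and two saturated chain carbons gives an at least 14-fold higher number from compound 3 to compound 4 (1.15 log units; beyond the scatter), whereas the exchanges of methyl and hydrogen elsewhere on the chain stayed within the scatter. The other two steps point the same way, with an at least 8.9-fold higher number from compound 2 to compound 4 (0.95 log units; beyond the scatter) and an at least 15-fold higher number from compound 1 to compound 4 (1.19 log units; beyond the scatter), so this carbon proves far less tolerant of the change than the rest of the chain.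

From the compounds shown here alone, only compound 4 carries methyl on that carbon, so it stays open whether that methyl alone or the whole 1,1-dimethylpropyl group accounts for the step. Going by these compounds, how tert-butyl or 1-methylcyclopropyl on the double-bonded nitrogen would read also remains open.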